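Tail amide to carbamate on the triazolylquinazoline series

The compounds below may be only part of what the source reports. "The series", "measured", "known", "first", "only" and "open" are said of these compounds alone.

Three compounds have numbers in an assay on MCF7 cells for inhibition of Serine-protein kinase ATM (Homo sapiens), read by immunofluorescence, with a stated time of 1 h; on this read-out lower numbers stand for stronger inhibition and higher numbers for weaker inhibition. Compound 1 `COc1ccc(-c2nc(N)n(-c3ncnc4ccccc34)n2)cc1` reaches only the limit of the assay and gives > 40000 nM. Compound 2 `COc1cc2ncnc(Nc3ccccn3)c2cc1OC` likewise reaches only the limit and gives > 40000 nM. Compound 3 `COc1cc2ncnc(-n3nc(-c4ccccn4)nc3N)c2cc1OCCCNC(=O)CN1C[C@@H](C)O[C@@H](C)C1` gives 1700 nM, the only number shown that is not a limit; the limit of > 40000 nM in this assay, at which 2 of the 3 values shown sit, sets the context in which it stands. Among the measured compounds shown here, no step between two measured compounds that differ in one place can be read from these values, so nothing about the influence of the tail is known from measurement.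

Compound 4 `COc1cc2ncnc(-n3nc(-c4ccccn4)nc3N)c2cc1OCCCNC(=O)OCC(F)(F)F` differs from compound 3 by 2,2,2-trifluoroethoxy in place of (2,6-dimethylmorpholin-4-yl)methyl on a carbonyl carbon. The shared core with its aminotriazole and pyridyl groups is unchanged, and the propoxy linker and its amide-type nitrogen are kept. For the measured compounds named here, with no measured step to lean on, the expectation for compound 4 is a value near that of compound 3, and a step of a 1.5-fold higher number from compound 3 to compound 4 (0.17 log units; within the scatter) of no more than a modest loss is expected. Compound 4 is therefore estimated at 2500 nM, with a range from 700 nM to 9000 nM.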

Compound 4, half-maximal inhibitory concentration: 1200 nM
Estimate against measurement, compound 4: 2.1-fold (0.32 log units) above, within the range that was stated.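

In this assay, the change on the carbonyl carbon gives a 1.4-fold lower number from compound 3 to compound 4 (0.15 log units; within the scatter), so the two tails cannot be told apart on this read-out. The tail on this carbonyl carbon therefore need not carry the six-membered non-aromatic ring, its ring nitrogen or its 2 defined stereocentres for the value to stay at this level, and a carbamate-type link reads the same as the amide-type link of compound 3. No measured property bears on why these two different groups read alike.

As far as these compounds go, whether a primary amine, a carboxylic acid or a longer chain on this carbonyl carbon would read the same stays open. Among the compounds shown here, how much of the value depends on the tail at all also stays open, as no step from compound 1 or compound 2 can be read.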